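Replacing the azidomethyl arm of compound 1 with a dichlorophenylethenyl

The source may report more compounds than this note shows. Statements on the series, on what has been measured and on what is new or still open speak of the compounds shown alone.

Compound 1 `[N-]=[N+]=NCc1nnc(-c2cc(S(N)(=O)=O)c(SCc3ccccc3)cc2Cl)o1` is known in an ADME assay on microsomes from liver (Homo sapiens) for metabolic stability, read by LC-MS, using NADPH, tested at 5 uM (a lower number here means that the compound disappears faster, a higher number that the compound lasts longer), only through a limit: in this assay compound 1 gives > 1 h, which is a limit of the assay and not a number, so compound 1 stands at the limit of > 1 h in this assay, at which 1 of the 3 values shown sits, and its exact place among the measured compounds is open. Compound 2 `NS(=O)(=O)c1cc(-c2nnc(Cn3cc(-c4ccccc4)nn3)o2)c(Cl)cc1SCc1ccccc1` gives 0.21 h in this assay, and compound 3 `NS(=O)(=O)c1cc(-c2nnc(/C=C/c3cccc(Cl)c3)o2)c(Cl)cc1SCc1ccccc1` gives 0.352 h. The steps of an at least 4.7-fold lower number from compound 1 to compound 2 (0.67 log units; beyond the scatter) and an at least 2.8-fold lower number from compound 1 to compound 3 (0.45 log units; beyond the scatter) both run downward, whereas a 1.7-fold higher number from compound 2 to compound 3 (0.22 log units; within the scatter). Compound 4 `NS(=O)(=O)c1cc(-c2nnc(/C=C/c3c(Cl)cccc3Cl)o2)c(Cl)cc1SCc1ccccc1` differs from compound 1 by 2-(2,6-dichlorophenyl)ethenyl in place of azidomethyl on an aromatic carbon. For the measured compounds named here, the measured step that bears most directly on this change is the one from compound 1 to compound 3, where 2-(3-chlorophenyl)ethenyl took the place of azidomethyl on the same aromatic carbon. The expected step is an at least 2.8-fold lower number from compound 1 to compound 4 (0.45 log units; beyond the scatter), a decrease about as large as that found for compound 3. Compound 4 is therefore estimated to give 0.35 h in this assay, within a range from 0.15 h to 0.8 h.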

Compound 4, half-life: 0.468 h
Estimate against measurement, compound 4: 1.3-fold (0.13 log units) below; low and high end bracket the measured number.
By their numbers in this assay, from the lowest: compounds 2, 3 and 4 (each within the scatter of the next, the first and the last beyond it). At a limit, above all of these: compound 1.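

In this assay, 2,6-dichlorophenyl in place of 3-chlorophenyl on the ethenyl arm leaves the two compounds within the scatter of each other, with a 1.3-fold higher number from compound 3 to compound 4 (0.12 log units; within the scatter). Against the (4-phenyl-1H-1,2,3-triazol-1-yl)methyl arm on the same aromatic carbon, the new arm gives a 2.2-fold higher number from compound 2 to compound 4 (0.35 log units; beyond the scatter), and this step passes the scatter, whereas the step from that arm to the 3-chlorophenyl ethenyl arm did not. The 2-(2,6-dichlorophenyl)ethenyl arm still ends up under azidomethyl, with an at least 2.1-fold lower number from compound 1 to compound 4 (0.32 log units; beyond the scatter).

On these data alone, the true size of that drop stays open, as compound 1 is known only through a limit of the assay and not a number: the limit of > 1 h in this assay, at which 1 of the 4 values shown sits. Also open, as far as these compounds go, is how an amine or a carboxylic acid on the phenyl ring of the arm, or a longer chain in place of ethenyl, would fare in this assay.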